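The source may hold more compounds than are shown below. What is called first, only, known or untested is meant among the compounds shown, and "the series" means these compounds.

Three compounds that share one core were examined in a functional assay on PC-3 cells (Homo sapiens) for antiproliferative activity, read by MTT assay, with a stated time of 72 h; on this read-out higher numbers stand for weaker inhibition and lower numbers for stronger inhibition. Compound 1 `C=CC(=O)Nc1cc2c(N3CCc4ccccc43)ncnc2cc1O[C@@H]1CCOC1` gives 2710 nM. Compound 2 `CC(C)/C=C/C(=O)Nc1cc2c(N3CCc4ccccc43)ncnc2cc1O[C@@H]1CCOC1` gives 11200 nM, and compound 3 `CCC/C=C/C(=O)Nc1cc2c(N3CCc4ccccc43)ncnc2cc1O[C@@H]1CCOC1` gives 9230 nM. Compound 3 therefore holds the second highest of the three numbers: the step of a 1.2-fold lower number from compound 2 to compound 3 (0.08 log units; within the scatter) lies within the scatter, whereas the step of a 3.4-fold higher number from compound 1 to compound 3 (0.53 log units; beyond the scatter) lies beyond it. The step of a 4.1-fold higher number from compound 1 to compound 2 (0.62 log units; beyond the scatter) points the same way, so in both cases a longer chain in place of vinyl on the carbonyl carbon raised the number, and the two chains did not separate from one another.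

Compound 4 `CCN(CC)C/C=C/C(=O)Nc1cc2c(N3CCc4ccccc43)ncnc2cc1O[C@@H]1CCOC1` has not yet been measured in this assay. It differs from compound 3 by diethylamino in place of ethyl on a saturated chain carbon bound to a double-bonded chain carbon. Among the compounds with values here, no measured step covers a change of this kind. Within the data shown here, the only step at that saturated chain carbon, a 1.2-fold lower number from compound 2 to compound 3 (0.08 log units; within the scatter), stayed within the scatter, and the steps of a 4.1-fold higher number from compound 1 to compound 2 (0.62 log units; beyond the scatter) and a 3.4-fold higher number from compound 1 to compound 3 (0.53 log units; beyond the scatter) show only that a substituted chain on the carbonyl carbon weakens activity relative to plain vinyl, which compound 4 retains. The step expected is therefore a 2.1-fold lower number from compound 3 to compound 4 (0.31 log units; beyond the scatter), small and uncertain in direction. Compound 4 is estimated at 4500 nM, with a range from 1200 nM to 18000 nM.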

Compound 4, half-maximal inhibitory concentration: 5780 nM
For compound 4 the middle estimate is 1.3-fold (0.11 log units) below the measured one; low and high end bracket the measured number.
By their numbers in this assay, from the lowest: compound 1; then compounds 4, 3 and 2 (each within the scatter of the next).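

In this assay, within the data shown here, diethylamino in place of ethyl on a saturated chain carbon bound to a double-bonded chain carbon puts a nitrogen into this chain for the first time, yet a 1.6-fold lower number from compound 3 to compound 4 (0.20 log units; within the scatter) stays within the scatter. The same holds for (diethylamino)methyl in place of isopropyl, with a 1.9-fold lower number from compound 2 to compound 4 (0.29 log units; within the scatter) also within the scatter, so compounds 2, 3 and 4 cannot be told apart on this read-out. Against plain vinyl, the 3-(diethylamino)prop-1-en-1-yl chain still shows a 2.1-fold higher number from compound 1 to compound 4 (0.33 log units; beyond the scatter) as a modest step, so diethylamino at this carbon does not bring the number back to that of compound 1. Nothing available explains why these chains behave alike.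

The compounds shown leave open whether a smaller amine such as dimethylamino, or a ring amine such as piperidine or morpholine, at the same saturated chain carbon would separate from diethylamino. They also leave open whether a carboxylic acid or a hydroxyl group there would move the number beyond the scatter in either direction.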